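A few compounds are considered here, and "the series" means these few. Any claim that something is new, unique, unknown or untested is made for them only; others in the source may bear on it.

Compound 2, `NCCCC[C@H](NC(=O)c1cc2ccccc2cn1)C(=O)OCc1ccccc1`, is the starting point. In a functional assay on the whole organism (CCRF S-180 cells, Mus musculus) for inhibition, in a xenograft, with stated times of 7 days and 24 h, at a dose of 100 umol/kg by the intraperitoneal route (on this read-out higher numbers stand for more inhibition at the one dose given (going by the name of the read-out) and lower numbers for less inhibition), compound 2 gives 40.6%, and it stands level with compound 1, `C[C@H](NC(=O)c1cc2ccccc2cn1)C(=O)OCc1ccccc1`, which in this assay gives 40.6%. Among the compounds with values here, the one measured step, no change at the digits printed from compound 1 to compound 2 (within the scatter), shows that adding a whole 3-aminopropyl group on a saturated chain carbon, two bonds along the chain from an amide-type nitrogen and a carbonyl carbon, left the read-out unchanged within the scatter.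

Compound 3, `O=C(N[C@@H](CO)C(=O)OCc1ccccc1)c1cc2ccccc2cn1`, differs from compound 2 at that same place: hydroxy in place of 3-aminopropyl on a saturated chain carbon, two bonds along the chain from an amide-type nitrogen and a carbonyl carbon. Within the data shown here, the only step that bears on this position is the one from compound 1 to compound 2, and it was flat, so a small group there is expected to make no difference beyond the scatter either; the step from compound 2 to compound 3 in this assay is therefore estimated as a number 0.6 percentage points lower from compound 2 to compound 3 (within the scatter). Compound 3 is expected to give about 40%, most likely between 26% and 54%.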

Compound 3, a percentage reported as inhibition, in the whole organism at one dose (the size of the read-out at that dose, not a potency): 40.4%
The estimate for compound 3 lay 0.4 percentage points below the measured number; the measured number falls inside the stated range.
By their numbers in this assay, from the lowest: compounds 3, 1 and 2 (each within the scatter of the next).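

In this assay, hydroxy in place of 3-aminopropyl leaves a number 0.2 percentage points lower from compound 2 to compound 3 (within the scatter), and hydroxy in place of hydrogen leaves a number 0.2 percentage points lower from compound 1 to compound 3 (within the scatter). The earlier pair showed only that 3-aminopropyl could replace hydrogen on this saturated chain carbon without a change beyond the scatter; now a third group, with one heavy atom against four for 3-aminopropyl, also reads level, so at this one dose neither the amine nor the number of heavy atoms separates these three compounds. Nothing available here explains why the read-out stays flat at this position.

From the compounds shown here alone, whether a carboxylic acid or a longer chain ending in a phenyl ring at this same place would read differently stays open. Going by these compounds, these values also come from a single dose, so how the three compounds compare at other doses stays open too.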